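Ethyl on the amide nitrogen of compound 2

A few compounds are considered here, and "the series" means these few. Any claim that something is new, unique, unknown or untested is made for them only; others in the source may bear on it.

Compound 1 (`O=C(O)c1ccc(-c2nn(Cc3ccccc3)c3ccccc23)cc1`) in a functional assay on cells (Platelet, Homo sapiens) for inhibition; a higher number here means a weaker inhibitor, a lower number a stronger inhibitor: > 10000 nM
Compound 2 (`NC(=O)c1ccc(-c2nn(Cc3ccccc3)c3ccccc23)cc1`) in this assay: > 10000 nM

Compound 2 stands only at a limit of the assay, > 10000 nM. Neither compound has yielded a number, as the limit of > 10000 nM in this assay, at which 2 of the 2 values shown sit, shows. Compound 3 (`CCNC(=O)c1ccc(-c2nn(Cc3ccccc3)c3ccccc23)cc1`) carries ethyl in place of hydrogen on an amide-type nitrogen. For the measured compounds named here, the only measured step bearing on this is a step that the two limits leave unreadable from compound 1 to compound 2, and it offers no size to carry over. No step beyond the scatter is therefore expected in this assay, and no direction can be given. The expected step is a step that the limit leaves unreadable from compound 2 to compound 3. Compound 3 is estimated at 12000 nM, with an expected range from 3000 nM to 40000 nM.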

Compound 3, half-maximal inhibitory concentration: > 10000 nM
Compound 3 ended at the assay's limit (the forecaster's own chance of this, stated with the estimate: 70%); the middle value does not contradict the limit.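

No new step can be read between compound 3 and either compound 1 or compound 2, because all three stop at the same limit: the limit of > 10000 nM in this assay, at which 3 of the 3 values shown sit.

The compounds shown leave open how strongly any of the three inhibits in this assay.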